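The source may report more compounds than this note shows. Statements on the series, on what has been measured and on what is new or still open speak of the compounds shown alone.

In a functional assay on MDA-MB-231 cells (Homo sapiens) for antiproliferative activity, read by MTT assay, with a stated time of 24 h (on this read-out lower numbers stand for stronger inhibition and higher numbers for weaker inhibition), compound 1 `COc1ccc(C(=O)/C=C/c2cc(-c3cc(OC)c(OC)c(OC)c3)n3nc(-c4ccccc4)cc3n2)cc1` gives 13200 nM, compound 2 `COc1ccc(-c2cc(/C=C/C(=O)c3ccc(OC)c(OC)c3)nc3cc(-c4ccccc4)nn23)cc1` gives 8700 nM, and compound 3 `COc1ccc(C(=O)/C=C/c2cc(-c3ccc(OC)c(OC)c3)n3nc(-c4ccccc4)cc3n2)cc1` gives 13900 nM. The number for compound 3 cannot be told apart from those of compound 1 and compound 2, since each of the gaps lies within the scatter. Compound 4 `COc1ccc(C(=O)/C=C/c2cc(-c3ccc(OC)cc3)n3nc(-c4ccccc4)cc3n2)cc1` differs from compound 3 in one place: hydrogen in place of methoxy on an aromatic carbon. Within the data shown here, one measured step bears on this, the loss of a methoxy group on the same ring, and it gave a 1.1-fold higher number from compound 1 to compound 3 (0.02 log units; within the scatter). On that basis the step of a 1.1-fold higher number from compound 3 to compound 4 (0.03 log units; within the scatter) is expected to stay within the scatter, with no clear direction. Compound 4 is therefore estimated to give about 15000 nM in this assay, within a range of 6000 nM to 40000 nM.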

Compound 4, half-maximal inhibitory concentration: 6300 nM
For compound 4 the middle estimate is 2.4-fold (0.38 log units) above the measured one; low and high end bracket the measured number.
By their numbers in this assay, from the lowest: compounds 4, 2, 1 and 3 (each within the scatter of the next, the first and the last beyond it).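

Going from 3,4-dimethoxyphenyl to 4-methoxyphenyl has a modest but readable effect at this position, with a 2.2-fold lower number from compound 3 to compound 4 (0.34 log units; beyond the scatter), which the earlier loss of a methoxy group on this ring did not show. The full change from 3,4,5-trimethoxyphenyl gives a 2.1-fold lower number from compound 1 to compound 4 (0.32 log units; beyond the scatter), also modest. A step on another core, with a 1.4-fold lower number from compound 2 to compound 4 (0.14 log units; within the scatter), stays small, and the two smaller steps cannot be told apart: the same change on two cores in this assay, a 1.1-fold higher number (0.02 log units; within the scatter) from compound 1 to compound 3 and a 1.4-fold lower number (0.14 log units; within the scatter) from compound 2 to compound 4, 1.5-fold (0.16 log units) apart, within the scatter of two such steps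

Open, from the compounds shown here alone, is what happens when the remaining methoxy group gives way to hydrogen, a fluorine atom or an amine.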